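From Fluoro to Chloro on a Shared Core

A few compounds are considered here, and "the series" means these few. Any claim that something is new, unique, unknown or untested is made for them only; others in the source may bear on it.

Compound 1 `O=c1oc2ccc(F)cc2c(=O)n1-c1ccc(I)cc1F` with 2050 nM
Compound 2 `O=C(Nc1ccc(Br)cc1F)c1cc(Cl)ccc1O` with 2140 nM

Both numbers come from a functional assay on RAW264.7 cells (Mus musculus) for inhibition, read by microscopy, with a stated time of 4 days, in the presence of a further agent that is not named here (a lower number here means a stronger inhibitor, a higher number a weaker inhibitor), and sit within the usual scatter of repeated measurements. Compound 1 therefore stands level with compound 2, and neither can be ranked above the other.

Compound 3 `O=c1oc2ccc(Cl)cc2c(=O)n1-c1ccc(I)cc1F` has not been measured yet. It keeps the core of compound 1 and differs in a single place chloro in place of fluoro on an aromatic carbon. That carbon belongs to a six-membered aromatic ring of carbon only, part of a fused system of two rings.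

Within the data shown here, no two measured compounds differ in just one place, so the data do not show directly how far such a swap moves the number in this assay and any forecast is uncertain. Compound 2, which also carries a chloro group, gives 2140 nM in the same test, so that group is at least compatible with activity of this order. The expected 1.3-fold lower number from compound 1 to compound 3 (0.11 log units; within the scatter) is small, leaning slightly toward a lower number and probably not beyond the scatter. For compound 3 the estimated value is 1600 nM with an expected range from 600 nM to 4000 nM in this assay for now.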

Compound 3, half-maximal inhibitory concentration: 2050 nM
For compound 3 the middle estimate is 1.3-fold (0.11 log units) below the measured one; the range from low to high includes it.
By their numbers in this assay, from the lowest: compounds 1, 3 and 2 (each within the scatter of the next).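

In this assay, among these compounds, putting chloro in place of fluoro on this aromatic carbon of the shared core gives no change at the digits printed from compound 1 to compound 3 (within the scatter), and this is the first direct reading of what a single change does in this small set. At this carbon, with the rest of compound 1 held fixed, the two halogens cannot be told apart by this test, so the swap neither gains nor loses anything that can be measured here. No accompanying measurement speaks to why the number stays put, so the result records an outcome and offers no explanation.

One pair of halogens on one carbon says little about how much change this place can accept, and an amine, a carboxylic acid or a longer chain on the same carbon could leave the number alone or shift it well beyond the scatter. Going by these compounds, it also remains open whether chloro and fluoro would stay just as interchangeable here if another part of the shared core were altered at the same time.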